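The source may report more compounds than this note shows. Statements on the series, on what has been measured and on what is new or still open speak of the compounds shown alone.

Measured compounds:
Compound 1, `Cn1ncc(Cl)c1-c1cc(C(=O)N[C@@H]2CN[C@H](CCN3CCCC3)C[C@H]2c2ccc(Cl)c(Cl)c2)oc1Cl`, gives 6.41 nM in an assay for inhibition of RAC-alpha serine/threonine-protein kinase (Homo sapiens), read by HTRF, with a stated time of 1 h; a lower number here means a stronger inhibitor, a higher number a weaker inhibitor.
Compound 2, `Cn1ncc(Cl)c1-c1cc(C(=O)N[C@@H]2CN[C@H](CCNS(C)(=O)=O)C[C@H]2c2ccc(F)c(F)c2)oc1Cl`, gives 3.29 nM in this assay.

Compound 1 holds the higher of the two numbers obtained so far, but its nearest neighbour, compound 2, lies within the usual scatter of the measurement, so no order can be drawn between them. Compound 2 also differs from compound 1 in more than one place, so nothing can be said about any single change from those two values alone.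

Compound 3, `CCC[C@@H]1C[C@@H](c2ccc(Cl)c(Cl)c2)[C@H](NC(=O)c2cc(-c3c(Cl)cnn3C)c(Cl)o2)CN1`, is the unmeasured partner of compound 1. The change is methyl in place of pyrrolidin-1-yl on a saturated chain carbon, two bonds along the chain from a saturated ring carbon. Among the measured compounds shown here, there is no measured pair to calibrate this step, so the expectation rests only on the two values seen and on the size of the group removed. A moderate weakening is expected in this assay, somewhat beyond the scatter but not large. The step is estimated as a 2.5-fold higher number from compound 1 to compound 3 (0.40 log units; beyond the scatter). Compound 3 is expected to give 16 nM, with a range from 4 nM to 65 nM.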

Compound 3, half-maximal inhibitory concentration: 10.4 nM
The estimate for compound 3 lay 1.5-fold (0.19 log units) above the measured number; low and high end bracket the measured number.
By their numbers in this assay, from the lowest: compounds 2, 1 and 3 (each within the scatter of the next, the first and the last beyond it).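

In this assay, putting methyl in place of pyrrolidin-1-yl on a saturated chain carbon, two bonds along the chain from a saturated ring carbon, gives a 1.6-fold higher number from compound 1 to compound 3 (0.21 log units; within the scatter) and so sets no order between the two compounds. This is the only comparison shown that isolates one place, and it indicates that the 2-(pyrrolidin-1-yl)ethyl chain of compound 1 can give way to the propyl chain of compound 3, losing the five-membered ring and its nitrogen, with no change that stands clear of the scatter. No measurement shown accounts for this outcome or tells what the pyrrolidin-1-yl group does at this position.

As far as these compounds go, whether a primary amine, a carboxylic acid or a longer chain at this place would also leave the number within the scatter remains open, and a single step cannot show how far this tolerance extends. From the compounds shown here alone, it is also open whether the same change would read alike with the two fluorines of compound 2 in place of the two chlorines on the aromatic ring.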